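Swapping the Aryl Ring on the Sulfonyl Sulfur

The compounds below may be only part of what the source reports. "The series", "measured", "known", "first", "only" and "open" are said of these compounds alone.

For compound 2 `CC(O)(C(=O)Nc1ccc(S(=O)(=O)c2ccc(Br)cc2)cc1)C(F)(F)F` the assay a functional assay (Cavia porcellus) with sulfonylurea receptors; K-ATP channels (Homo sapiens) as the target (a lower number here means a stronger inhibitor, a higher number a weaker inhibitor), reports only a limit, > 30000 nM (the limit of > 30000 nM in this assay, at which 1 of the 2 values shown sits). Compound 1 `CC(O)(C(=O)Nc1ccc(S(=O)(=O)c2cccc(O)c2)cc1)C(F)(F)F` gives 18000 nM in this assay. Among the compounds with values here, the only measured step touching the sulfonyl sulfur is an at least 1.6-fold higher number from compound 1 to compound 2 (0.22 log units; that floor lies within the scatter), and its floor lies within the scatter. Compound 3 `CC(O)(C(=O)Nc1ccc(S(=O)(=O)c2cncnc2)cc1)C(F)(F)F` carries the change (pyrimidin-5-yl in place of 4-bromophenyl on a sulfonyl sulfur). Within the data shown here, no measured step covers a pyrimidine ring, so no move beyond the scatter is expected, and the estimated step of an at least 1.0-fold lower number from compound 2 to compound 3 (0.02 log units; that floor lies within the scatter) is small. Compound 3 is therefore expected to give about 28000 nM, with a range from 9000 nM to 90000 nM, and a limit may again be all the assay reports.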

Compound 3, half-maximal inhibitory concentration: > 30000 nM
Compound 3: a limit, no number; the forecaster's own chance of this, stated with the estimate: 55%; middle value at least 1.0-fold (0.02 log units) from the limit.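

In this assay compound 3 again gives only a limit, so neither a pyrimidin-5-yl ring nor a 4-bromophenyl ring on the sulfonyl sulfur yields a number, and the step between compound 2 and compound 3 cannot be read. Within the data shown here, the one readable new step, an at least 1.6-fold higher number from compound 1 to compound 3 (0.22 log units; that floor lies within the scatter), has a floor within the scatter, so it does not separate pyrimidin-5-yl from 3-hydroxyphenyl. The values now gather at the assay's limit: the limit of > 30000 nM in this assay, at which 2 of the 3 values shown sit.

Compound 1 alone keeps a number. Going by these compounds, whether an aminophenyl or a carboxyphenyl ring on the sulfonyl sulfur would move the value beyond the scatter stays open.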